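Methyl in Place of Fluoro on the Urea Aryl

A few compounds are considered here, and "the series" means these few. Any claim that something is new, unique, unknown or untested is made for them only; others in the source may bear on it.

Of the compounds shown here, two sharing one core have been measured in a functional assay on MKN-45 cells (Homo sapiens) for cytotoxicity, read by MTT assay, with a stated time of 72 h; a higher number here means a weaker inhibitor, a lower number a stronger inhibitor. Compound 1 `CN(C)CCCNc1nc(-c2ccc(NC(=O)Nc3ccccc3Cl)cc2)nc2ccsc12` gives 690 nM, while compound 2 `CN(C)CCNc1nc(-c2ccc(NC(=O)Nc3ccc(F)cc3)cc2)nc2ccsc12` gives 330 nM, the lower of the two numbers; the gap between compound 1 and compound 2 lies beyond the usual scatter of repeated measurements of this kind, so on the numbers shown compound 2 stands as the stronger inhibitor of the pair.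

Compound 3 `Cc1ccc(NC(=O)Nc2ccc(-c3nc(NCCN(C)C)c4sccc4n3)cc2)cc1` is a single-site variant of compound 2: methyl in place of fluoro on an aromatic carbon, in words methyl in place of fluoro on an aromatic carbon, the aryl ring of the urea going from 4-fluorophenyl to 4-methylphenyl. Going by the values given here, no measured pair in this set isolates that swap, so there is no step to lean on. The two groups are each one heavy atom, uncharged, and add no donors or acceptors. The expected step from compound 2 to compound 3 is therefore small, a 1.3-fold higher number from compound 2 to compound 3 (0.10 log units; within the scatter), in either direction or none beyond the scatter. For compound 3 in this assay the estimate is 420 nM, with a range from 150 nM to 1200 nM.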

Compound 3, half-maximal inhibitory concentration: 2380 nM
Compound 3: middle estimate off by 5.7-fold (0.75 log units), on the low side; measured number above the stated range.
By their numbers in this assay, from the lowest: compound 2; then compound 1; then compound 3.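

In this assay, the change from 4-fluorophenyl to 4-methylphenyl on the urea brings a 7.2-fold higher number from compound 2 to compound 3 (0.86 log units; beyond the scatter), so this position, on an aromatic carbon para to a large group, does not tolerate every small group equally. The two groups match in each count available, with one heavy atom apiece, no hydrogen-bond donors or acceptors and no net charge, so those counts do not separate them, yet the read-out does. Going by these compounds alone, this is the first single-site comparison in the set, since compound 1 and compound 2 differ in more than one place, and nothing measured here bears on what lies behind the step.

As far as these compounds go, what remains open is whether methyl is unfavourable at this position or fluoro is specifically favourable, a question that plain hydrogen, chloro or methoxy in the same place would help to settle. From the compounds shown here alone, it is also open whether the step carries over when the dimethylaminoethyl chain of compound 2 and compound 3 is replaced by a longer chain or by a morpholine.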